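The source may hold more compounds than are shown below. What is called first, only, known or untested is meant among the compounds shown, and "the series" means these compounds.

Measured in a functional assay on MCF7 cells (Homo sapiens) for antiproliferative activity, read by MTT assay, with a stated time of 72 h; a lower number here means a stronger inhibitor, a higher number a weaker inhibitor:
- compound 1 `CCCCCCCCNC[C@@H]1OC[C@H](N)[C@@H]1O` gives 96600 nM
- compound 2 `CCCCCCCCCCCCNC[C@@H]1OC[C@H](N)[C@H]1O` gives 12600 nM
- compound 3 `CCCCCCCCCNC[C@@H]1OC[C@H](N)[C@H]1O` gives 60300 nM

Compound 3 lies within the scatter of compound 1, while compound 2 has a lower value than compound 3, beyond the scatter. Compound 4 `CCCCCCCNC[C@@H]1OC[C@H](N)[C@H]1O` carries hydrogen in place of ethyl on a saturated chain carbon, seven bonds along the chain from an amine nitrogen. For the measured compounds named here, one measured step bears on this change, with hydrogen in place of propyl (a 4.8-fold higher number from compound 2 to compound 3 (0.68 log units; beyond the scatter)). A single step is thin evidence, but a rise of similar or somewhat smaller size is expected in this assay, beyond the scatter. The expected change is a 2.5-fold higher number from compound 3 to compound 4 (0.40 log units; beyond the scatter). The estimated value for compound 4 is 150000 nM (expected range 70000 nM to 320000 nM).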

Compound 4, half-maximal inhibitory concentration: > 128000 nM
Compound 4: only a limit was reported; the forecaster's own chance of this, stated with the estimate: 25%; the middle value does not contradict the limit.
By their numbers in this assay, from the lowest: compound 2; then compounds 3 and 1 (each within the scatter of the next). At a limit, above all of these: compound 4.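

In this assay compound 4 is reported only as a limit: the limit of > 128000 nM in this assay, at which 1 of the 4 values shown sits. Even so, the loss on shortening the chain continues at this short end, with an at least 2.1-fold higher number from compound 3 to compound 4 (0.32 log units; beyond the scatter), and hydrogen in place of pentyl gives an at least 10-fold higher number from compound 2 to compound 4 (1.00 log units; beyond the scatter). Among compound 2, compound 3 and compound 4 the number therefore rises with each shortening, though the true size of the last rise stays unknown.

From the compounds shown here alone, whether a longer chain than that of compound 2 lowers the number further remains open. So does whether an amine or a carboxylic acid on the chain is tolerated.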